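Swapping Chloro for Methyl on a Weak Sigma-2 Binder

This account rests on a few compounds, and the source may have more. Where it says the series, first, only, none or still open, it means among the compounds named here.

The three measured compounds share one core and differ only in the aromatic group attached to it; all were tested in an assay on membranes from Jurkat cells for displacement of a labelled ligand from Sigma intracellular receptor 2 (Homo sapiens), read by scintillation counting, with a stated time of 1 h; a higher number here means a weaker inhibitor, a lower number a stronger inhibitor. Compound 1 `Cn1nc(CN2CCCC2)nc1-c1ccc(Cl)cc1` gives a limit rather than a number, > 1000 nM. Compound 2 `Cn1nc(CN2CCCC2)nc1-c1cccc(Oc2ccccc2)c1` likewise reaches only a limit, > 1000 nM. Compound 3 `Cn1nc(CN2CCCC2)nc1-c1ccc2cc(Cl)sc2c1` gives 1000 nM, which sits at the same level. Compound 1 thus stands at the weak end of what this assay can record, a position described by the limit of > 1000 nM in this assay, at which 2 of the 3 values shown sit.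

Compound 4 `Cc1ccc(-c2nc(CN3CCCC3)nn2C)cc1` differs from compound 1 in one place: methyl in place of chloro on an aromatic carbon. For the measured compounds named here, no pair of measured compounds shows a change of this kind, so nothing here tells how it moves binding. The step that the limit leaves unreadable from compound 1 to compound 4 is expected to be none beyond the scatter. Compound 4 is expected to give about 2000 nM, in a range from 600 nM to 8000 nM, most likely again reported only as a limit.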

Compound 4, inhibition constant: > 1000 nM
Compound 4 ended at the assay's limit (the forecaster's own chance of this, stated with the estimate: 60%); the middle value lies beyond the limit too.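

No size can be read for the swap of chloro for methyl between compound 1 and compound 4, because both values are limits of the assay: the limit of > 1000 nM in this assay, at which 3 of the 4 values shown sit. The compounds shown leave open whether this swap moves binding in this assay at all.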